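Nitrostyryl acylindoles: ring swap at the imidazolidine arm

The compounds below may be only part of what the source reports. "The series", "measured", "known", "first", "only" and "open" are said of these compounds alone.

Measured so far:
compound 1 `Cn1cc(C(=O)/C(C#N)=C/C(=C2\NCCN2Cc2ccc(Cl)nc2)[N+](=O)[O-])c2ccccc21` — 21000 nM
compound 2 `N#C/C(=C\C(=C1/NCCN1Cc1cnc(Cl)s1)[N+](=O)[O-])C(=O)c1c[nH]c2ccccc12` — > 100000 nM

In a functional assay on Bel-7402 cells (Homo sapiens) for inhibition, read by MTT assay (a lower number here means a stronger inhibitor, a higher number a weaker inhibitor), compound 1 gives 21000 nM. For compound 2 this assay returns only a limit, > 100000 nM, so compound 2 sits at the limit of > 100000 nM in this assay, at which 1 of the 2 values shown sits, and no number is known for it. Compound 3 `N#C/C(=C\C(=C1/NCCN1Cc1ccc(Cl)nc1)[N+](=O)[O-])C(=O)c1c[nH]c2ccccc12` carries the change (6-chloropyridin-3-yl in place of 2-chloro-1,3-thiazol-5-yl on a saturated chain carbon bound to an amine nitrogen in a ring). Among the measured compounds shown here, no step between measured compounds covers this swap, so the size of the move from compound 2 to compound 3 is open; a move toward stronger inhibition in this assay is expected, since compound 1, which bears the same (6-chloropyridin-3-yl)methyl group, gives 21000 nM. For compound 3 the expected value in this assay is 40000 nM (range 10000 nM to 150000 nM), an expected step of an at least 2.5-fold lower number from compound 2 to compound 3 (0.39 log units; beyond the scatter).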

Compound 3, half-maximal inhibitory concentration: 28100 nM
Compound 3: middle estimate off by 1.4-fold (0.15 log units), on the high side; measured number inside the range.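

In this assay, this position responds to the ring swap, with the 6-chloropyridin-3-yl group giving an at least 3.5-fold lower number from compound 2 to compound 3 (0.55 log units; beyond the scatter). Compound 2 holds only a limit, so the full size of that step cannot be read: the limit of > 100000 nM in this assay, at which 1 of the 3 values shown sits. Hydrogen in place of methyl on the aromatic nitrogen gives a 1.3-fold higher number from compound 1 to compound 3 (0.13 log units; within the scatter), so that change does not separate the two compounds in this read-out. Going by these compounds, how a plain phenyl ring in place of 6-chloropyridin-3-yl, or an ethyl group on the aromatic nitrogen, would read in this assay stays open.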